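Hydroxymethyl for cyano on a biphenyl cyclohexylcarbamate

A few compounds are considered here, and "the series" means these few. Any claim that something is new, unique, unknown or untested is made for them only; others in the source may bear on it.

Measured so far in an assay on cell membranes for binding affinity to Fatty-acid amide hydrolase 1 (Rattus norvegicus); on this read-out higher numbers stand for weaker inhibition and lower numbers for stronger inhibition:
Compound 1, `O=C(NC1CCCCC1)Oc1cccc(-c2cccc(OC(=O)NC3CCCCC3)c2)c1`: 361 nM
Compound 2, `N#Cc1cccc(-c2cccc(OC(=O)NC3CCCCC3)c2)c1`: 33.9 nM

Among these two compounds, compound 2 stands lowest in this assay; its nearest neighbour is compound 1, and the step from it is an 11-fold lower number from compound 1 to compound 2 (1.03 log units; beyond the scatter). The next compound to be weighed is compound 3, `O=C(NC1CCCCC1)Oc1cccc(-c2cccc(CO)c2)c1`. Its difference from compound 2 is hydroxymethyl in place of cyano on an aromatic carbon. Among the compounds with values here, no measured step exchanges these two groups directly. Within the data shown here, the only step at hand, an 11-fold lower number from compound 1 to compound 2 (1.03 log units; beyond the scatter), shows that the group on this aromatic carbon can move the number strongly, so a change there is not to be taken as neutral. Among the measured compounds shown here, with no direct precedent, compound 3 is expected to stay near compound 2, and the estimated step of a 1.1-fold lower number from compound 2 to compound 3 (0.05 log units; within the scatter) is taken as within the scatter. Compound 3 is therefore estimated at 30 nM in this assay, with a range from 8 nM to 120 nM.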

Compound 3, half-maximal inhibitory concentration: 8.67 nM
Estimate against measurement, compound 3: 3.5-fold (0.54 log units) above; the range from low to high includes it.
By their numbers in this assay, from the lowest: compound 3; then compound 2; then compound 1.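

In this assay, a 3.9-fold lower number from compound 2 to compound 3 (0.59 log units; beyond the scatter) shows that this position on the 3-cyanophenyl ring has not reached its lowest number with cyano, and that exchanging it for hydroxymethyl, a group that carries a hydrogen-bond donor where cyano has none, still moves the number beyond the scatter. Measured against the large (cyclohexylcarbamoyl)oxy group, a 42-fold lower number from compound 1 to compound 3 (1.62 log units; beyond the scatter) places compound 3 lowest of the three compounds, with its steps to both others beyond the scatter. Nothing at hand explains why hydroxymethyl gives the lower number here.

The compounds shown leave open whether the hydroxyl hydrogen is needed for this gain, which a methoxymethyl group would test. They also leave open how an aminomethyl group, a carboxylic acid or a longer chain such as hydroxyethyl would compare at this place.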